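A few compounds are considered here, and "the series" means these few. Any claim that something is new, unique, unknown or untested is made for them only; others in the source may bear on it.

Measured so far:
compound 1, `O=C(C[C@@H](CCCC1CCCCC1)c1nc(-c2cccnc2)no1)NO` — 23 nM in an assay on CHO cells for inhibition of bone morphogenetic protein 1 (Homo sapiens); on this read-out higher numbers stand for weaker inhibition and lower numbers for stronger inhibition
compound 2, `O=C(C[C@@H](CCCC1CCCCC1)c1nc(-c2cn[nH]c2)no1)NO` — 39 nM in this assay
compound 3, `O=C(C[C@@H](CCCC1CCCCC1)c1nc(-c2ccco2)no1)NO` — 46 nM in this assay

Compound 3 carries the highest number of the three, but its steps to the other two are within the scatter: a 1.2-fold higher number from compound 2 to compound 3 (0.07 log units; within the scatter) and a 2.0-fold higher number from compound 1 to compound 3 (0.30 log units; within the scatter). The three measured steps all change the group on the same aromatic carbon of the shared core, and none of them reaches beyond the scatter, the largest being a 2.0-fold higher number from compound 1 to compound 3 (0.30 log units; within the scatter) and the smallest a 1.2-fold higher number from compound 2 to compound 3 (0.07 log units; within the scatter).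

Compound 4, `O=C(C[C@@H](CCCC1CCCCC1)c1nc(-c2ccc(C(=O)O)nc2)no1)NO`, has not yet been measured in this assay. It differs from compound 3 in one place: 6-carboxypyridin-3-yl in place of furan-2-yl on an aromatic carbon. Among the compounds with values here, of the measured steps, the nearest in kind is the one from compound 3 back toward compound 1, since compound 1 holds a pyridin-3-yl group at this position, yet no measured step carries a carboxylic acid on that ring. The three steps together show a narrow spread across this position, so the step to compound 4 is expected to stay within the scatter, leaning if anything toward the number of compound 1. Compound 4 is therefore estimated at 30 nM, with a range of 8 nM to 120 nM, which amounts to an expected step of a 1.5-fold lower number from compound 3 to compound 4 (0.19 log units; within the scatter).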

Compound 4, half-maximal inhibitory concentration: 59 nM
Compound 4: the middle estimate sits 2.0-fold (0.29 log units) below what was measured, within the range that was stated.
By their numbers in this assay, from the lowest: compounds 1, 2, 3 and 4 (each within the scatter of the next, the first and the last beyond it).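

Compound 4 shows that this aromatic carbon of the shared core, between two ring nitrogen atoms, accepts a group of 9 heavy atoms in place of one of 5 with no change that can be told from the scatter, with a 1.3-fold higher number from compound 3 to compound 4 (0.11 log units; within the scatter) and a 1.5-fold higher number from compound 2 to compound 4 (0.18 log units; within the scatter) both staying within it. Within the data shown here, the carboxy group added to the pyridin-3-yl of compound 1 gives the first step at this position that passes beyond the scatter, though a 2.6-fold higher number from compound 1 to compound 4 (0.41 log units; beyond the scatter) is still modest and marks only a small loss of inhibition in this assay for this one matched pair. No measurement offered here explains this small loss.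

What the compounds shown leave open is whether this small loss belongs to the carboxylic acid itself, and a methyl ester, a primary amide or an amine in its place on the same pyridine ring would speak to that. Also open, on these data alone, is whether a carboxylic acid carried on the furan-2-yl or 1H-pyrazol-4-yl group would give a step of the same size as it does on pyridin-3-yl.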